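A few compounds are considered here, and "the series" means these few. Any claim that something is new, unique, unknown or untested is made for them only; others in the source may bear on it.

So far, these values have been measured in a functional assay on MCF7 cells (Homo sapiens) for antiproliferative activity, read by sulforhodamine B assay, with a stated time of 48 h (on this read-out higher numbers stand for weaker inhibition and lower numbers for stronger inhibition), for the three compounds:

- compound 1 (`COc1ccccc1OS(=O)(=O)c1ccc(N2CCN(C)C2=O)cc1`) gives 26000 nM
- compound 2 (`CN1CCN(c2ccc(S(=O)(=O)Oc3cccc(F)c3)cc2)C1=O`) gives > 100000 nM as a limit of the assay, not a number
- compound 3 (`CN1CCN(c2ccc(S(=O)(=O)Oc3cccc(Cl)c3)cc2)C1=O`) gives 2200 nM

Within the data shown here, only two of these values are true numbers, and compound 1 at 26000 nM holds the higher one, which means the weaker inhibition. The gap to the other number is large (a 12-fold lower number from compound 1 to compound 3 (1.07 log units; beyond the scatter)).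

Compound 4 (`CCCCN1CCN(c2ccc(S(=O)(=O)Oc3ccccc3OC)cc2)C1=O`) keeps the core of compound 1 and differs in one place (propyl in place of hydrogen on a saturated chain carbon bound to an amide-type nitrogen in a ring). The same change can also be read as methyl to butyl.

Two further measured steps (an at least 3.8-fold higher number from compound 1 to compound 2 (0.58 log units; beyond the scatter)) and (an at least 45-fold lower number from compound 2 to compound 3 (1.65 log units; beyond the scatter)) are also beyond the scatter. All three steps, however, change the aromatic group on the oxygen, and none touches this chain. They show that small edits elsewhere in these compounds can move the number a long way, but they give neither a size nor a direction for a longer chain. The best starting point is therefore compound 1 (26000 nM) itself, with no step beyond the scatter firmly expected and a wide margin on either side.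

The expected step is small (a 1.9-fold lower number from compound 1 to compound 4 (0.27 log units; within the scatter)) on this reasoning. For compound 4 the estimated value is 14000 nM with an expected range from 2500 nM to 70000 nM in this rough guess.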

Compound 4, half-maximal inhibitory concentration: 3800 nM
Estimate against measurement, compound 4: 3.7-fold (0.57 log units) above; measured number inside the range.
By their numbers in this assay, from the lowest: compounds 3 and 4 (each within the scatter of the next); then compound 1. At a limit, above all of these: compound 2.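

Until now, every measured step changed the aromatic group on the oxygen, so nothing showed whether the chain on the amide-type nitrogen in a ring could move the number at all. In this assay the change from methyl to butyl gives a 6.8-fold lower number from compound 1 to compound 4 (0.84 log units; beyond the scatter) and so counts as a modest gain in inhibition, which makes this chain a second place in these compounds where an edit matters. No measurement shown here bears on what lies behind this step, which rests on one pair of compounds with the 2-methoxyphenyl group.

Open, from the compounds shown here alone, is how the number follows chain length: an ethyl chain could show whether the change builds gradually, and a hexyl chain or a butyl chain ending in an amine could show whether it continues, levels off or turns back. Also open, going by these compounds, is whether butyl in place of methyl would give a similar step on compound 3, which carries the 3-chlorophenyl group, so the two changes may or may not add up.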